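The source may hold more compounds than are shown below. What is called first, only, known or untested is meant among the compounds shown, and "the series" means these compounds.

Measured compounds:
compound 1 `CC1=CC[C@H]2[C@H](CC[C@]2(C)O)C(C)(C)[C@@H]1CC[C@H]1[C@]2(C)CC[C@H](OC(=O)c3ccncc3)C(C)(C)O[C@H]2CC[C@@]1(C)O` — 25300 nM
compound 2 `CC1=CC[C@H]2[C@@H]1CC=C(C)[C@@H](CC[C@H]1[C@]3(C)CC[C@H](OCc4ccccc4)C(C)(C)O[C@H]3CC[C@@]1(C)O)C2(C)C` — > 50000 nM

In a functional assay on MCF7 cells (Homo sapiens) for antiproliferative activity, read by MTT assay, with a stated time of 72 h (a lower number here means a stronger inhibitor, a higher number a weaker inhibitor), compound 1 gives 25300 nM. Among the measurements here this is the only proper number, and it marks a weak inhibitor. Compound 2 is recorded only as a limit, namely (the limit of > 50000 nM in this assay, at which 1 of the 2 values shown sits), so for compound 2 no number is known. Among the compounds with values here, the two compounds share a core but carry different groups on the ring oxygen, and no pair of measured compounds differs in a single place, so no measured step can be read off.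

Compound 3 `CC1=CC[C@H]2[C@H](CC[C@]2(C)O)C(C)(C)[C@@H]1CC[C@H]1[C@]2(C)CC[C@H](OC(=O)c3ccccc3[N+](=O)[O-])C(C)(C)O[C@H]2CC[C@@]1(C)O` has not yet been measured. It differs from compound 1 in one place: 2-nitrophenyl in place of pyridin-4-yl on a carbonyl carbon. Since nothing measured here tells how an aromatic group on the carbonyl carbon shifts the result, the best guide is compound 1 itself. The step from compound 1 to compound 3 is expected to be small, within the usual scatter, a 1.0-fold lower number from compound 1 to compound 3 (0.01 log units; within the scatter). Compound 3 is therefore estimated at 25000 nM in this assay, with a likely range from 8000 nM to 80000 nM.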

Compound 3, half-maximal inhibitory concentration: 5200 nM
For compound 3 the middle estimate is 4.8-fold (0.68 log units) above the measured one; measured number below the stated range.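

Putting 2-nitrophenyl in place of pyridin-4-yl on the carbonyl carbon, with the rest of the molecule unchanged, gives in this assay a 4.9-fold lower number from compound 1 to compound 3 (0.69 log units; beyond the scatter). Within the data shown here, this is the first measured step, and it shows that the aromatic group held on this carbonyl carbon can shift the result by more than repeat measurements would, so this position does influence antiproliferative activity in these cells. The step is modest, however, and it bundles two changes, since the ring loses its nitrogen and becomes a ring of carbon only while also gaining a nitro group, so this single comparison cannot separate the two.

On these data alone, it remains open whether a plain phenyl group, with no nitro group, would give a number like that of compound 3, and whether an amino group or a methoxy group in place of the nitro group would do the same. Nothing in the measurements shown explains why this change lowers the number.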